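The compounds below may be only part of what the source reports. "The series", "measured", "known", "first", "only" and "open" are said of these compounds alone.

Measured compounds:
- Compound 1, `Cc1cc(Nc2ccc(C(=O)/C=C/c3ccc4ccccc4c3)cc2)n2nc(SCc3ccc(F)cc3)nc2n1`; in a functional assay on SW-620 cells (Homo sapiens) for cytotoxicity, read by MTT assay, with stated times of 4 h and 72 h, tested at 5 uM (on this read-out higher numbers stand for weaker inhibition and lower numbers for stronger inhibition), compound 1 gives 320 nM.
- Compound 2, `Cc1cc(Nc2ccc(C(=O)/C=C/c3ccc4ccccc4c3)cc2)n2nc(SCc3ccc(Cl)cc3)nc2n1`; compound 2 gives 570 nM.
- Compound 3, `Cc1cc(Nc2ccc(C(=O)/C=C/c3ccc4ccccc4c3)cc2)n2nc(SCc3ccccc3)nc2n1`; compound 3 gives 300 nM.

All three share the same core and differ only in the group on the benzylsulfanyl ring. Compound 3 has the lowest number of the three, but its steps to the others are small: a 1.1-fold lower number from compound 1 to compound 3 (0.03 log units; within the scatter) and a 1.9-fold lower number from compound 2 to compound 3 (0.28 log units; within the scatter), both within the scatter, so the three compounds cannot be ranked against one another.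

Compound 4, `Cc1cc(Nc2ccc(C(=O)/C=C/c3ccc4ccccc4c3)cc2)n2nc(SCc3cccc([N+](=O)[O-])c3)nc2n1`, is the unmeasured compound. It differs from compound 3 by nitro in place of hydrogen on an aromatic carbon. Among the compounds with values here, no measured step involves a nitro group, so the only guidance comes from the changes already seen on this same ring: fluoro, chloro and hydrogen all gave numbers within the scatter of each other. On that basis the expected step in this assay is a 1.3-fold higher number from compound 3 to compound 4 (0.12 log units; within the scatter), with no clear direction beyond the scatter, though the range is kept wide since a nitro group is a new kind of change here. Compound 4 is therefore estimated at 400 nM, between 150 nM and 1100 nM.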

Compound 4, half-maximal inhibitory concentration: 790 nM
Estimate against measurement, compound 4: 2.0-fold (0.30 log units) below; the range from low to high includes it.
By their numbers in this assay, from the lowest: compounds 3, 1, 2 and 4 (each within the scatter of the next, the first and the last beyond it).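

In this assay, within the data shown here, the ring of the benzylsulfanyl group now shows a change that can be told apart from noise: there is a 2.6-fold higher number from compound 3 to compound 4 (0.42 log units; beyond the scatter) and also a 2.5-fold higher number from compound 1 to compound 4 (0.39 log units; beyond the scatter), the first steps on this ring to lie beyond the scatter, though both are modest. The separation is only partial, since a 1.4-fold higher number from compound 2 to compound 4 (0.14 log units; within the scatter) stays within the scatter, so the nitro group stands apart from hydrogen and from the 4-fluorophenyl group but not from the 4-chlorophenyl group of compound 2. Nothing measured here explains why the number moves with this change.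

Compound 4 differs from compound 1 and compound 2 in two ways at once, since its 3-nitrophenyl group has a different substituent at a different ring place, and so the effect of the nitro group cannot be separated from the effect of where it sits. The compounds shown also leave open how this ring would behave with an amine, a carboxylic acid or a methoxy group on it, and whether any such group would move the number further than nitro does.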